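A few compounds are considered here, and "the series" means these few. Any claim that something is new, unique, unknown or untested is made for them only; others in the source may bear on it.

Working notes on the series. All four compounds share one core, and differ only in the group on one aromatic carbon of it. Compound 1 `O=C1O[C@H]([C@@H](O)Cn2cc(-c3cccc(O)c3)nn2)C(OCc2ccccc2)=C1OCc1ccccc1` bears 3-hydroxyphenyl there; in a functional assay on HCT-116 cells (Homo sapiens) for antiproliferative activity, read by MTT assay, with a stated time of 72 h (a lower number here means a stronger inhibitor, a higher number a weaker inhibitor), compound 1 gives 42900 nM. Compound 2 `O=C1O[C@H]([C@@H](O)Cn2cc(CNS(=O)(=O)c3ccc(F)cc3)nn2)C(OCc2ccccc2)=C1OCc1ccccc1` has (((4-fluorophenyl)sulfonyl)amino)methyl in the same place, and in this assay compound 2 gives 22900 nM, a change of a 1.9-fold lower number from compound 1 to compound 2 (0.27 log units; within the scatter). Compound 3 `Cc1ccc(-c2cn(C[C@H](O)[C@H]3OC(=O)C(OCc4ccccc4)=C3OCc3ccccc3)nn2)cc1` carries 4-methylphenyl. In this assay compound 3 gives > 100000 nM, which is a limit of the assay rather than a number. Compound 3 therefore stands at the limit of > 100000 nM in this assay, at which 1 of the 3 values shown sits. The two measured steps that reach it, an at least 2.3-fold higher number from compound 1 to compound 3 (0.36 log units; beyond the scatter) and an at least 4.3-fold higher number from compound 2 to compound 3 (0.64 log units; beyond the scatter), both run toward that limit.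

Compound 4 `O=C1O[C@H]([C@@H](O)Cn2ccnn2)C(OCc2ccccc2)=C1OCc1ccccc1` is the next step: hydrogen in place of 4-methylphenyl on an aromatic carbon. For the measured compounds named here, only an at least 2.3-fold higher number from compound 1 to compound 3 (0.36 log units; beyond the scatter) and an at least 4.3-fold higher number from compound 2 to compound 3 (0.64 log units; beyond the scatter) touch compound 3, and both concern an exchange of one group for another; no measured step removes the group entirely. With the value of compound 3 known only as a limit, the direction of the step in this assay cannot be read from the numbers shown, and the expectation is simply another weak inhibitor, with a number no higher from compound 3 to compound 4 (the limit leaves the size open) as the estimated step. Compound 4 is expected to give about 100000 nM in this assay, within 30000 nM to 300000 nM.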

Compound 4, half-maximal inhibitory concentration: > 100000 nM
Compound 4: only a limit was reported; the forecaster's own chance of this, stated with the estimate: 60%; the middle value sits exactly at the limit.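

Compound 4, with only hydrogen on this aromatic carbon, returns a limit of the assay in this assay, the same limit that compound 3 reaches: the limit of > 100000 nM in this assay, at which 2 of the 4 values shown sit. For the compounds shown here, this is the first view of the position with no group on it, and the loss against the two compounds that gave a number is beyond the scatter: hydrogen in place of (((4-fluorophenyl)sulfonyl)amino)methyl gives an at least 4.3-fold higher number from compound 2 to compound 4 (0.64 log units; beyond the scatter), and hydrogen in place of 3-hydroxyphenyl gives an at least 2.3-fold higher number from compound 1 to compound 4 (0.36 log units; beyond the scatter). The step from compound 3 to compound 4 cannot be read, since both ends are limits, so 4-methylphenyl and hydrogen cannot be told apart here, and the shared core with hydrogen alone gives no number in this series, while the groups of compound 1 and compound 2 do.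

As far as these compounds go, how far compound 3 and compound 4 lie past their limit stays unknown, so any order between them remains open. From the compounds shown here alone, whether an aminomethyl group, a carboxylic acid or a longer chain on this aromatic carbon would give a number in this assay is also open.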